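The source may report more compounds than this note shows. Statements on the series, on what has been measured and on what is new or still open speak of the compounds shown alone.

Measured in a functional assay on HepG2 cells (Homo sapiens), read by MTT assay, with a stated time of 48 h; a higher number here means a weaker inhibitor, a lower number a stronger inhibitor:
- compound 1 `CCn1c(C(=O)NCCCN(C)C)ccc1C(CC)(CC)c1ccc(OCC(=O)C(C)(C)C)c(C)c1`: 960 nM
- compound 2 `CCOC(=O)CN(C)C(=O)c1ccc(C(CC)(CC)c2ccc(OCC(O)C(C)(C)C)c(C)c2)n1CC`: > 50000 nM (a limit of the assay, not a number)
- compound 3 `CCn1c(C(=O)NCCN(C)C)ccc1C(CC)(CC)c1ccc(OCC(O)C(C)(C)C)c(C)c1`: 870 nM

Compound 3 at 870 nM and compound 1 at 960 nM lie within the scatter of each other. Among the measured compounds shown here, they are the only two numbers, since compound 2 is reported only as a limit.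

Compound 4 `CCn1c(C(=O)NCCCN(C)C)ccc1C(CC)(CC)c1ccc(OCC(O)C(C)(C)C)c(C)c1` is not yet measured. It differs from compound 3 by one change, ((dimethylamino)methyl in place of dimethylamino on a saturated chain carbon, two bonds along the chain from an amide-type nitrogen), which reads as (2-(dimethylamino)ethyl)amino to (3-(dimethylamino)propyl)amino.

For the measured compounds named here, the one measured step is large: an at least 57-fold lower number from compound 2 to compound 3 (1.75 log units; beyond the scatter). It exchanges a different group on a carbonyl carbon, so it does not give the size of this chain extension. The closer guide is compound 1, which carries (3-(dimethylamino)propyl)amino on its carbonyl carbon and gives 960 nM, a value within the scatter of compound 3. On that basis, no shift beyond the scatter is expected in this assay, in either direction. The expected size is a 1.0-fold higher number from compound 3 to compound 4 (0.01 log units; within the scatter). For compound 4 the estimated value is 900 nM, with an expected range from 400 nM to 2200 nM.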

Compound 4, half-maximal inhibitory concentration: 360 nM
Beside the measured number, compound 4's estimate is 2.5-fold (0.40 log units) above it; the measured number lies below the stated range.
By their numbers in this assay, from the lowest: compound 4; then compounds 3 and 1 (each within the scatter of the next). At a limit, above all of these: compound 2.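

In this assay, among the compounds shown here, lengthening the chain from (2-(dimethylamino)ethyl)amino to (3-(dimethylamino)propyl)amino on the carbonyl carbon gives the first reading of chain length alone at this position, with the 1-hydroxy-2,2-dimethylpropyl group held constant: a 2.4-fold lower number from compound 3 to compound 4 (0.38 log units; beyond the scatter). With the (3-(dimethylamino)propyl)amino chain held constant, the other end of the molecule also proves responsive, as 1-hydroxy-2,2-dimethylpropyl in place of (tert-butyl)carbonyl gives a 2.7-fold lower number from compound 1 to compound 4 (0.43 log units; beyond the scatter), so the closeness of the earlier values, from compounds differing in two places, did not show that either change is silent. The step on the carbonyl carbon, an at least 130-fold lower number from compound 2 to compound 4 (2.14 log units; beyond the scatter), starts from a limit of the assay, not a number: the limit of > 50000 nM in this assay, at which 1 of the 4 values shown sits.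

On these data alone, a single pair reads chain length, so it remains open whether a longer chain such as (4-(dimethylamino)butyl)amino would extend this step, and whether a pyrrolidine or a primary amine in place of dimethylamino would keep it. As far as these compounds go, the size of the 1-hydroxy-2,2-dimethylpropyl for (tert-butyl)carbonyl change on the (2-(dimethylamino)ethyl)amino chain also remains open.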